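The source may report more compounds than this note shows. Statements on the series, on what has been measured and on what is new or still open speak of the compounds shown alone.

Two compounds of the series have been run in a functional assay for agonist activity at G protein-coupled receptor 88 (Homo sapiens), read by HTRF and cAMP accumulation; a higher number here means that more compound is needed for the effect, a lower number that less compound is needed. Compound 1, `CC(C)CCNCCN(C(=O)[C@@H]1C[C@H]1c1ccccc1)c1ccc(-c2ccccc2)cc1`, gives 5.1 nM in this assay. Compound 2, `CC[C@H](C)[C@H](N)CN(C(=O)[C@@H]1C[C@H]1c1cccc(OC)c1)c1ccc(-c2ccccc2)cc1`, gives 3000 nM in this assay, the higher of the two numbers, and the gap between compound 2 and compound 1 is far beyond the scatter; the two structures differ in more than one place, so no single step can be read from them.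

Compound 3, `CC[C@H](C)[C@H](N)CN(C(=O)[C@@H]1C[C@H]1c1ccc(F)cc1F)c1ccc(-c2ccccc2)cc1`, has not yet been measured. It differs from compound 2 in one place: 2,4-difluorophenyl in place of 3-methoxyphenyl on a saturated ring carbon. For the measured compounds named here, no step of this kind, a methoxyphenyl to a difluorophenyl on a saturated ring carbon, appears anywhere among the measured compounds, so nothing here tells what size of change to expect from it. In the absence of any such step, the expectation is a change from compound 2 to compound 3 that is at most modest, in either direction, of about a 1.5-fold lower number from compound 2 to compound 3 (0.18 log units; within the scatter). The estimate for compound 3 in this assay is 2000 nM, with a range of 400 nM to 10000 nM.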

Compound 3, half-maximal effective concentration: 1300 nM
Estimate against measurement, compound 3: 1.5-fold (0.19 log units) above; the range from low to high includes it.
By their numbers in this assay, from the lowest: compound 1; then compound 3; then compound 2.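

Working notes: in this assay the first readable step at this position, on a saturated ring carbon of a three-membered ring, is a 2.3-fold lower number from compound 2 to compound 3 (0.36 log units; beyond the scatter). The aryl group on the cyclopropyl ring is therefore a place where the number moves, though only modestly for this exchange, in which a 3-methoxyphenyl with its hydrogen-bond acceptor gives way to a 2,4-difluorophenyl with none and the heavy-atom count stays the same. No measured evidence on these compounds bears on this result.

As far as these compounds go, with this single step, the methoxy group and the two fluorines cannot be separated, so it stays open whether a phenyl with one fluorine at either of those places, or a phenyl bearing a chlorine or a nitrile, would give a similar number. For the compounds shown here, it is also open whether the step would keep its size with the 3-methylbutylamino-ethyl chain of compound 1 on the amide nitrogen, since compound 1 differs from compound 2 and compound 3 in more than one place and no step to it can be read.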